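A few compounds are considered here, and "the series" means these few. Any claim that something is new, unique, unknown or untested is made for them only; others in the source may bear on it.

Compound 1, `Cc1ccc(-c2cs/c(=N/NC(=O)CSc3nnnn3-c3ccccc3)n2-c2ccccc2)cc1`: in an ADME assay on NIH3T3 cells (Mus musculus) for cytotoxicity, read by MTT assay, with a stated time of 24 h (on this read-out higher numbers stand for weaker inhibition and lower numbers for stronger inhibition), compound 1 gives > 500 ug/mL, a limit of the assay.
Compound 2, `Cc1ccc(-c2cs/c(=N/NC(=O)CSc3ncccn3)n2-c2ccccc2)cc1`: compound 2 gives > 500 ug/mL, likewise a limit.
Compound 3, `COc1ccc(-c2cs/c(=N/NC(=O)CSc3nnnn3C)n2-c2ccccc2)cc1`: compound 3 gives 45 ug/mL.

Compound 1 thus stands at the limit, together with one other of the three values (the limit of > 500 ug/mL in this assay, at which 2 of the 3 values shown sit). Among the measured compounds shown here, the single measured step from it, a step that the two limits leave unreadable from compound 1 to compound 2, lies between two limits and gives no readable size, and it sits on the sulfur, not on the phenyl ring. Compound 4, `O=C(CSc1nnnn1-c1ccccc1)N/N=c1/scc(-c2ccc(Br)cc2)n1-c1ccccc1`, differs from compound 1 by bromo in place of methyl on an aromatic carbon. For the measured compounds named here, no measured step bears on this change, so no direction beyond the scatter can be read for it in this assay. Compound 4 is therefore expected near the limit, at 350 ug/mL between 120 ug/mL and 500 ug/mL. The expected step is an at least 1.4-fold lower number from compound 1 to compound 4 (0.15 log units; that floor lies within the scatter).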

Compound 4, half-maximal inhibitory concentration: 433 ug/mL
Compound 4: middle estimate off by 1.2-fold (0.09 log units), on the low side; low and high end bracket the measured number.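

With bromo in place of methyl on this aromatic carbon, the read-out in this assay becomes a number rather than a limit. The change gives an at least 1.1-fold lower number from compound 1 to compound 4 (0.06 log units; that floor lies within the scatter), so no shift beyond the usual scatter is shown at this position. The value of compound 1 remains a limit, and it is not the only one: the limit of > 500 ug/mL in this assay, at which 2 of the 4 values shown sit.

Left open is how a chloro group, an amine or a carboxylic acid on this aromatic carbon would read in this assay. Also open, from the compounds shown here alone, is whether bromo would read the same with pyrimidin-2-yl on the sulfur.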